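The source may report more compounds than this note shows. Statements on the series, on what has been measured and on what is new or still open speak of the compounds shown alone.

Measured compounds:
compound 1 `COc1cc(Nc2ncnc3c(NC(=O)Nc4cc(Cl)cc(Cl)c4)cccc23)cc(OC)c1` – 30.2 nM
compound 2 `COc1cc(Nc2ncnc3c(NC(=O)Nc4cc(F)cc(F)c4)cccc23)cc(OC)c1` – 2630 nM
compound 3 `COc1cc(Nc2ncnc3c(NC(=O)Nc4cccc(C(F)(F)F)c4F)cccc23)cc(OC)c1` – 471 nM

In a functional assay on RT-112 cells (Homo sapiens) for antiproliferative activity, read by MTT assay, with a stated time of 72 h (a lower number here means a stronger inhibitor of growth, a higher number a weaker inhibitor of growth), compound 1 gives the lowest of the three numbers; the steps of a 16-fold higher number from compound 1 to compound 3 (1.19 log units; beyond the scatter) and an 87-fold higher number from compound 1 to compound 2 (1.94 log units; beyond the scatter) both go well beyond the scatter. Compound 4 `COc1cc(Nc2ncnc3c(NC(=O)c4cc(=O)c5ccccc5o4)cccc23)cc(OC)c1` is not yet measured. It differs from compound 1 by a group of 11 heavy atoms (9 carbon, 2 oxygen; one six-membered aromatic ring of carbon only, one six-membered aromatic ring with 1 hetero atom) in place of a group of 9 heavy atoms (6 carbon, 1 nitrogen, 2 chlorine; one six-membered aromatic ring of carbon only), on a carbonyl carbon. Among the measured compounds shown here, no measured step alters this same position in this same way, so the two aryl exchanges, an 87-fold higher number from compound 1 to compound 2 (1.94 log units; beyond the scatter) and a 16-fold higher number from compound 1 to compound 3 (1.19 log units; beyond the scatter), are the only guide, and both were large losses. Compound 4 is therefore expected to show a sizeable loss, roughly a 9.9-fold higher number from compound 1 to compound 4 (1.00 log units; beyond the scatter), with wide uncertainty. The estimate for compound 4 is 300 nM, between 50 nM and 3000 nM.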

Compound 4, concentration for 50% growth inhibition: > 20000 nM
Compound 4: no number, only a limit (the forecaster's own chance of this, stated with the estimate: 5%); middle value at least 66-fold (1.82 log units) from the limit.
By their numbers in this assay, from the lowest: compound 1; then compound 3; then compound 2. At a limit, above all of these: compound 4.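

In this assay compound 4 gives no number but a limit of the assay: the limit of > 20000 nM in this assay, at which 1 of the 4 values shown sits. Exchanging the whole (3,5-dichlorophenyl)amino group on the carbonyl carbon costs more than either aryl exchange, with an at least 660-fold higher number from compound 1 to compound 4 (2.82 log units; beyond the scatter). Compound 4 also falls beyond the two weaker compounds, with an at least 42-fold higher number from compound 3 to compound 4 (1.62 log units; beyond the scatter) and an at least 7.6-fold higher number from compound 2 to compound 4 (0.88 log units; beyond the scatter).

The compounds shown do not separate the loss of the amino nitrogen, with its hydrogen-bond donor, from the entry of the two-ring group. On these data alone, how a simple benzylamine or a carboxylic acid at this carbonyl carbon would behave remains open.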